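The source may report more compounds than this note shows. Statements on the series, on what has been measured and on what is new or still open speak of the compounds shown alone.

Three compounds share one nucleoside core, and each has been read in an ADME assay on HEL cells (Homo sapiens) for cytotoxicity, read by microscopy; a lower number here means that less compound is tolerated, a higher number that more compound is tolerated. Compound 1 `O=c1[nH]c(=O)n([C@H]2C[C@H](O)[C@@H](CO)O2)cc1C#CC#Cc1ccccc1` gives 100000 nM. Compound 2 `CCCCCCc1ccc(C#CC#Cc2cn([C@H]3C[C@H](O)[C@@H](CO)O3)c(=O)[nH]c2=O)cc1`, carrying hexyl in place of hydrogen on an aromatic carbon, gives 100000 nM, so that no change at the digits printed from compound 1 to compound 2 (within the scatter). For compound 3 `O=c1[nH]c(=O)n([C@H]2C[C@H](O)[C@@H](CO)O2)cc1C#CC#Cc1ccccn1` the result in this assay is a limit of the assay, > 20000 nM, and not a number. Because of that limit of > 20000 nM in this assay, at which 1 of the 3 values shown sits, the step that the limit leaves unreadable from compound 1 to compound 3. Compound 3 thus stands on a limit, not on a measured value.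

Compound 4 `Nc1ccc(C#CC#Cc2cn([C@H]3C[C@H](O)[C@@H](CO)O3)c(=O)[nH]c2=O)cc1` differs from compound 3 by 4-aminophenyl in place of pyridin-2-yl on a triple-bonded carbon. Among the measured compounds shown here, of the two measured steps, only the one from compound 1 to compound 2 can be read, and it lies within the scatter; the one from compound 1 to compound 3 is unreadable. For the measured compounds named here, no measured step bears directly on the change to compound 4, and no movement beyond the scatter is expected in this assay. Compound 4 is expected to give 100000 nM, between 20000 nM and 100000 nM. The expected step is a step that the limit leaves unreadable from compound 3 to compound 4.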

Compound 4, minimum cytotoxic concentration: > 100000 nM
Compound 4 was reported as a limit; the forecaster's own chance of this, stated with the estimate: 60%; the middle value sits exactly at the limit.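

In this assay compound 4 gives > 100000 nM as a limit of the assay and not a number. On the aromatic carbon, amino in place of hydrogen gives a number no lower from compound 1 to compound 4 (the limit leaves the size open) and amino in place of hexyl gives a number no lower from compound 2 to compound 4 (the limit leaves the size open) for this change, so a ring carrying amino, like the rings carrying hydrogen or hexyl, shows no fall in the tolerated concentration. The remaining step, to compound 4 from the pyridin-2-yl group of compound 3, cannot be read, because compound 3 also stands on a limit: the limit of > 20000 nM in this assay, at which 1 of the 4 values shown sits.

From the compounds shown here alone, how much compound 4 would tolerate beyond its limit stays open, and so does any ranking of the two groups on the triple-bonded carbon. Going by these compounds, whether a carboxylic acid or a methyl group on the same ring would keep the tolerated concentration at this level is also open.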